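This account rests on a few compounds, and the source may have more. Where it says the series, first, only, none or still open, it means among the compounds named here.

Compound 1 `Cc1cccc(CNC(=O)n2cnc3ccccc32)c1` and compound 2 `Cc1ccccc1CNC(=O)n1cnc2ccccc21` share one core and differ only in where a methyl sits on the outer benzene ring. In an assay on HEK293 cells for inhibition of acid ceramidase (Homo sapiens), read by fluorescence, with stated times of 30 min and 1 h (a lower number here means a stronger inhibitor, a higher number a weaker inhibitor), compound 1 gives 8.3 nM, while compound 2 gives 55.9 nM. Going by the values given here, of the two numbers known so far, compound 2 therefore carries the higher one, and its gap to compound 1 lies beyond the ordinary scatter of the assay. Compound 3 `Cc1ccccc1CNC(=O)n1c(N)nc2ccccc21` keeps everything in compound 2 and changes a single spot on the core: amino in place of hydrogen on an aromatic carbon. Among the compounds with values here, no measured pair shows what this particular change does, so the expectation rests on the change alone. It is estimated that the number will move somewhat upward, a step of a 2.7-fold higher number from compound 2 to compound 3 (0.43 log units; beyond the scatter) in this assay, though a result within the scatter would not surprise. Compound 3 is accordingly expected to give about 150 nM, within a range from 40 nM to 800 nM.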

Compound 3, half-maximal inhibitory concentration: 68.4 nM
Beside the measured number, compound 3's estimate is 2.2-fold (0.34 log units) above it, within the range that was stated.
By their numbers in this assay, from the lowest: compound 1; then compounds 2 and 3 (each within the scatter of the next).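

Putting amino on the aromatic carbon between two ring nitrogen atoms gives a 1.2-fold higher number from compound 2 to compound 3 (0.09 log units; within the scatter) in this assay, so the two numbers cannot be told apart. The earlier compounds shown here differed only on the outer benzene ring, whereas this pair shows that the shared core can take a small change at this spot, swapping a hydrogen for amino, with no readable effect on the number. The data shown offer no measurement that would explain this result.

On these data alone, it remains open whether this carbon would tolerate other groups in the same way, such as a methyl, a longer chain like propyl or a carboxylic acid. Also unknown is whether amino would behave the same way on compound 1, which has the lower number and carries its methyl elsewhere on the outer ring.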